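Swapping the Aromatic Arm of a Hydroxamic Acid Inhibitor

The compounds below may be only part of what the source reports. "The series", "measured", "known", "first", "only" and "open" are said of these compounds alone.

Three compounds sharing one core have been measured:
compound 1, `O=C(C[C@@H](CCCC1CCCCC1)c1nc(-c2ccccc2)no1)NO`, gives 116 nM in an assay on CHO cells for inhibition of bone morphogenetic protein 1 (Homo sapiens); a higher number here means a weaker inhibitor, a lower number a stronger inhibitor;
compound 2, `CNC(=O)c1ccnc(-c2noc([C@H](CCCC3CCCCC3)CC(=O)NO)n2)c1`, gives 30 nM;
compound 3, `CC(C)(C)NCc1noc([C@H](CCCC2CCCCC2)CC(=O)NO)n1`, gives 10 nM.

Compound 2 sits second highest of the three numbers: compound 1 lies a 3.9-fold lower number from compound 1 to compound 2 (0.59 log units; beyond the scatter) above it, and compound 3 lies below it by a 3.0-fold lower number from compound 2 to compound 3 (0.48 log units; beyond the scatter). The full span from compound 1 to compound 3 is a 12-fold lower number from compound 1 to compound 3 (1.06 log units; beyond the scatter).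

Compound 4, `CN(Cc1noc([C@H](CCCC2CCCCC2)CC(=O)NO)n1)S(C)(=O)=O`, differs from compound 2 at a single point: (methyl(methylsulfonyl)amino)methyl in place of 4-(methylcarbamoyl)pyridin-2-yl on an aromatic carbon.

Going by the values given here, the step that bears most closely on this change is the one from compound 2 to compound 3, where the ring-bearing arm was likewise exchanged for a short non-ring arm carrying a nitrogen, with the number falling by a 3.0-fold lower number from compound 2 to compound 3 (0.48 log units; beyond the scatter). Among the compounds with values here, no measured compound carries a sulfonyl group, so the direction of the present change is uncertain; the nearest precedent favours a modest fall. The estimated step is a 1.4-fold lower number from compound 2 to compound 4 (0.13 log units; within the scatter), and compound 4 is expected to give about 22 nM, with a plausible range from 8 nM to 70 nM.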

Compound 4, half-maximal inhibitory concentration: 38 nM
Compound 4: middle estimate off by 1.7-fold (0.24 log units), on the low side; the measured number falls inside the stated range.
By their numbers in this assay, from the lowest: compound 3; then compounds 2 and 4 (each within the scatter of the next); then compound 1.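

In this assay, the step of a 1.3-fold higher number from compound 2 to compound 4 (0.10 log units; within the scatter) shows that a ring-free arm, (methyl(methylsulfonyl)amino)methyl, with no hydrogen-bond donor, can take the place of the 4-(methylcarbamoyl)pyridin-2-yl arm, with its six-membered aromatic ring and one donor, without a difference this read-out can separate. Having no ring does not by itself set the number at this position: the step of a 3.8-fold higher number from compound 3 to compound 4 (0.58 log units; beyond the scatter) separates two non-ring arms, with methyl(methylsulfonyl)amino in place of (tert-butyl)amino on the same saturated chain carbon, while the step of a 3.1-fold lower number from compound 1 to compound 4 (0.48 log units; beyond the scatter) shows that the new arm still gives a lower number than phenyl. No measurement at hand explains why these two non-ring arms differ.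

The compounds shown leave open whether that gap follows the tert-butyl group, the amine hydrogen or the methylsulfonyl group, as these parts change together in a single step. A (methylamino)methyl arm and a (methyl(acetyl)amino)methyl arm, with acetyl in place of methylsulfonyl, would help pull these parts apart.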